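The source may hold more compounds than are shown below. What is called first, only, known or untested is meant among the compounds shown, and "the series" means these compounds.

Three compounds of this series have been run in a functional assay on L1210 cells (Mus musculus) for cytotoxicity; on this read-out lower numbers stand for stronger inhibition and higher numbers for weaker inhibition. Compound 1 `O=C(/C=C/C(=O)N1C/C(=C\c2ccc([N+](=O)[O-])cc2)C(=O)/C(=C/c2ccc([N+](=O)[O-])cc2)C1)Nc1ccc(Cl)c(Cl)c1` gives 1700 nM. Compound 2 `O=C(/C=C/C(=O)N1C/C(=C\c2ccc([N+](=O)[O-])cc2)C(=O)/C(=C/c2ccc([N+](=O)[O-])cc2)C1)Nc1ccc(Cl)cc1` gives 3600 nM. Compound 3 `O=C(/C=C/C(=O)N1C/C(=C\c2ccccc2)C(=O)/C(=C/c2ccccc2)C1)Nc1ccccc1` gives 3600 nM, level with compound 2 at the digits given and within the scatter of it. The difference between the core of compound 2 and the core of compound 3 is not broken down here. Between compound 2 and compound 1 the change is chloro in place of hydrogen on an aromatic carbon, and it gave a 2.1-fold lower number from compound 2 to compound 1 (0.33 log units; beyond the scatter). Compound 4 `O=C(/C=C/C(=O)N1C/C(=C\c2ccccc2)C(=O)/C(=C/c2ccccc2)C1)Nc1ccc(Cl)cc1` has not yet been measured; it differs from compound 3 by chloro in place of hydrogen on an aromatic carbon. This is the same kind of change as from compound 2 to compound 1, not the same: there the entering chloro sits ortho to a chloro group and meta to a large group, here it sits para to a large group, and the two cores differ. The expectation rests on a single recorded step, a 2.1-fold lower number from compound 2 to compound 1 (0.33 log units; beyond the scatter), made in the other core. A modest lowering is therefore expected, the step from compound 3 to compound 4 being estimated as a 1.5-fold lower number from compound 3 to compound 4 (0.18 log units; within the scatter). Compound 4 is estimated at 2400 nM. For compound 4 the expected range runs from 1200 nM to 5000 nM.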

Compound 4, half-maximal inhibitory concentration: 7800 nM
Compound 4: middle estimate off by 3.3-fold (0.51 log units), on the low side, and the stated range ends below it.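

In this assay, chloro in place of hydrogen on the core of compound 3 gives a 2.2-fold higher number from compound 3 to compound 4 (0.34 log units; beyond the scatter), so the direction seen on the other core does not carry over. The two steps disagree in direction and in the comparison of their sizes: the same change on two cores in this assay, a 2.1-fold lower number (0.33 log units; beyond the scatter) from compound 2 to compound 1 and a 2.2-fold higher number (0.34 log units; beyond the scatter) from compound 3 to compound 4, 4.6-fold (0.66 log units) apart, beyond the scatter of two such steps This shows that, across the compounds shown, the effect of this change cannot be transferred from one core to the other, but it does not show what sets the difference, as the cores differ and the ring receiving the chloro already carries one in compound 2 and none in compound 3.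

Open, from the compounds shown here alone, is how the plain phenylcarbamoyl group behaves on the core of compound 2, and how a second chloro on the ring of compound 4 behaves on the core of compound 3; those two results would separate the role of the core from that of the chloro already present. Also open, going by these compounds, is whether a fluoro or methoxy group at the same place follows compound 4 or compound 2 in direction.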